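Adding a chloro to the core of compound 2

A few compounds are considered here, and "the series" means these few. Any claim that something is new, unique, unknown or untested is made for them only; others in the source may bear on it.

Two compounds carry numbers in an assay on isolated protein for inhibition of 3-hydroxy-3-methylglutaryl-coenzyme A reductase (Rattus norvegicus); on this read-out lower numbers stand for stronger inhibition and higher numbers for weaker inhibition. Compound 1 `O=C1C[C@H](O)C[C@@H](/C=C/c2cccc3cccc(Br)c23)O1` gives 4120 nM. Compound 2 `O=C1C[C@H](O)CC(CCc2ccc(Cl)c3cc(Cl)ccc23)O1` gives 7000 nM, the highest of the two numbers, though the gap to compound 1 lies within the scatter, so the pair reads as one level. Compound 3 `O=C1C[C@H](O)CC(CCc2c(Cl)cc(Cl)c3cc(Cl)ccc23)O1` is not yet measured and differs from compound 2 by one change: chloro in place of hydrogen on an aromatic carbon. Within the data shown here, no step between measured compounds exists for such a change, so no shift beyond the scatter is expected in either direction. Compound 3 is expected to give 5000 nM in this assay, from 1500 nM to 16000 nM. The step of a 1.4-fold lower number from compound 2 to compound 3 (0.15 log units; within the scatter) is thus expected to stay within the scatter.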

Compound 3, half-maximal inhibitory concentration: 33 nM
Estimate against measurement, compound 3: 150-fold (2.18 log units) above; the measured number lies below the stated range.
By their numbers in this assay, from the lowest: compound 3; then compounds 1 and 2 (each within the scatter of the next).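

In this assay one chloro in place of hydrogen on an aromatic carbon, ortho to a large group, brings a 210-fold lower number from compound 2 to compound 3 (2.33 log units; beyond the scatter) and lifts the series clear of the level shared by compound 1 and compound 2. This place on the core therefore responds strongly to a single heavy atom, which the two earlier compounds could not reveal. Nothing at hand accounts for the size of this step. Going by these compounds, whether this response is specific to chloro remains open, since fluoro, methyl or methoxy at the same place would test that.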